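The source may hold more compounds than are shown below. What is called first, only, known or untested is meant among the compounds shown, and "the series" means these compounds.

Measured in an ADME assay on CCRF-HSB-2 cells (Homo sapiens) for cytotoxicity, with a stated time of 7 days; on this read-out higher numbers stand for lower toxicity in this test and lower numbers for higher toxicity in this test:
compound 1, `CC(C)CNc1nc(N)nc2c1ncn2/C=C1/CC1(CO)CO`: > 20000 nM
compound 2, `Nc1nc(NCc2ccccc2)c2ncn(/C=C3/CC3(CO)CO)c2n1`: > 20000 nM
compound 3, `Nc1nc2c(ncn2/C=C2/CC2(CO)CO)c(=O)[nH]1`: > 20000 nM

The value of compound 1 is a limit of this assay, not a number. The value of compound 2 is likewise a limit. The value of compound 3 is likewise a limit. Compound 2 therefore stands at the limit of > 20000 nM in this assay, at which 3 of the 3 values shown sit, and nothing in the numbers sets it apart from compound 1 or compound 3. Among the compounds with values here, the only step within the measured set is a step that the two limits leave unreadable from compound 1 to compound 2, which gives no readable size and no direction.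

Compound 4, `CCOc1nc(N)nc2c1ncn2/C=C1/CC1(CO)CO`, is to be measured in this assay. Against compound 2 the change is ethoxy in place of benzylamino on an aromatic carbon. Within the data shown here, no measured step covers this change, and the one step that touches compound 2 is unreadable, so no direction can be drawn from the data. For compound 4 the expected step is a number no higher from compound 2 to compound 4 (the limit leaves the size open), that is, nothing beyond the scatter is expected. Compound 4 is estimated at 20000 nM, with a range from 10000 nM to 40000 nM, and most probably only a limit will again be reported.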

Compound 4, half-maximal cytotoxic concentration: > 20000 nM
Compound 4 ended at the assay's limit; the forecaster's own chance of this, stated with the estimate: 85%; the middle value lies on the limit itself.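

In this assay, the steps from compound 1 and compound 2 to compound 4 cannot be read, and compound 4 gives only a limit: the limit of > 20000 nM in this assay, at which 4 of the 4 values shown sit.

The compounds shown leave open whether any group on this aromatic carbon changes the half-maximal cytotoxic concentration, as none gives a value short of the limit.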